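The compounds below may be only part of what the source reports. "The series", "measured", "known", "first", "only" and "open" are said of these compounds alone.

Working notes on the series. Lipophilicity is followed in a physicochemical assay for lipophilicity, using the shake flask method, in phosphate buffer, measured as octanol-water partition, with a stated time of 30 min, at pH 7.4; on this read-out higher numbers stand for higher lipophilicity and lower numbers for lower lipophilicity. Compound 1 `Cc1cc(-c2cnc(NCc3c(F)ccc4c3CCO4)c3cn[nH]c(=O)c23)n(C)n1` gives 3 in this assay, the highest of the three numbers measured. Compound 3 `CN(c1cccnc1)c1cnc(NCc2c(F)ccc3c2CCO3)n2cnnc12` gives 2.6 in this assay, and compound 2 `Cc1ncccc1-c1cnc(NCc2c(F)ccc3c2CCO3)c2nn(CC#N)c(=O)n12` gives 2.2, both lower than compound 1 by margins beyond the scatter.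

Compound 4 `Cc1nc(CO)ccc1-c1cnc(NCc2c(F)ccc3c2CCO3)c2cn[nH]c(=O)c12` has not been measured in this assay. From compound 1 to compound 4 the change is 6-(hydroxymethyl)-2-methylpyridin-3-yl in place of 1,3-dimethyl-1H-pyrazol-5-yl on an aromatic carbon. Going by the values given here, no measured pair isolates this exchange, so the expectation rests on the range of the three values. A step downward beyond the scatter is expected, a number 0.60 log units lower from compound 1 to compound 4 (beyond the scatter). For compound 4 a value of 2.4 is estimated in this assay, within 1.9 to 2.9.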

Compound 4, distribution coefficient: 2.4
The estimate for compound 4 equals the measured number at the digits printed; the measured number falls inside the stated range.
By their numbers in this assay, from the lowest: compounds 2, 4 and 3 (each within the scatter of the next, the first and the last beyond it); then compound 1.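

Going by these compounds alone, on the shared core, this position responds to the exchange in this assay: 6-(hydroxymethyl)-2-methylpyridin-3-yl in place of 1,3-dimethyl-1H-pyrazol-5-yl gives a number 0.60 log units lower from compound 1 to compound 4 (beyond the scatter), the first change read in one place. The exchange alters the ring and adds the hydroxymethyl together, so the step belongs to the whole group and not to either part. No evidence bears on the origin of the step.

As far as these compounds go, the separate shares of the ring and the hydroxymethyl remain open on this core. Also open, from the compounds shown here alone, is how a carboxylic acid or an aminomethyl group in place of the hydroxymethyl would read.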